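Replacing the Aromatic Substituent of Compound 1 by Methoxy

This account rests on a few compounds, and the source may have more. Where it says the series, first, only, none or still open, it means among the compounds named here.

Measured compounds:
compound 1 `COc1ccc(-c2cc(C(=O)N3CCC4(CC3)CC(=O)c3nn(C(C)(C)C)cc3O4)c3ccccc3n2)cc1`: 2780 nM
compound 2 `Cc1cc(C(=O)N2CCC3(CC2)CC(=O)c2nn(C(C)(C)C)cc2O3)c2ccccc2n1`: 9480 nM

Among the compounds with values here, in a functional assay on HepG2 cells (Homo sapiens) for inhibition, read by MTT assay, with a stated time of 72 h (on this read-out higher numbers stand for weaker inhibition and lower numbers for stronger inhibition), compound 1 stands lowest of the two numbers, with compound 2 as its only neighbour. Within the data shown here, the one measured step that bears on the new compound is a 3.4-fold higher number from compound 1 to compound 2 (0.53 log units; beyond the scatter), where methyl replaced the 4-methoxyphenyl. Compound 3 `COc1cc(C(=O)N2CCC3(CC2)CC(=O)c2nn(C(C)(C)C)cc2O3)c2ccccc2n1` carries the change methoxy in place of 4-methoxyphenyl on an aromatic carbon at the same place, again removing the aromatic group. A rise of similar, modest size is therefore expected, a 2.9-fold higher number from compound 1 to compound 3 (0.46 log units; beyond the scatter). Compound 3 is estimated at 8000 nM, within a range from 3000 nM to 22000 nM.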

Compound 3, half-maximal inhibitory concentration: > 10000 nM
Compound 3 was reported as a limit (the forecaster's own chance of this, stated with the estimate: 10%); middle value at least 1.2-fold (0.09 log units) away from the limit.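

The value of compound 3 in this assay is a limit and not a number: the limit of > 10000 nM in this assay, at which 1 of the 3 values shown sits.

Even so, replacing the 4-methoxyphenyl with methoxy gives an at least 3.5-fold higher number from compound 1 to compound 3 (0.55 log units; beyond the scatter), so a second small group on this aromatic carbon also ends up with weaker inhibition. Methoxy and methyl cannot be ordered here: the step is an at least 1.0-fold higher number from compound 2 to compound 3 (0.02 log units; that floor lies within the scatter).

As far as these compounds go, how far the true value of compound 3 lies past its limit stays open. Also open, from the compounds shown here alone, is how an unsubstituted phenyl ring or an amine at this place would read.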